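Lengthening the Amine Substituent on Two Related Cores

The source may hold more compounds than are shown below. What is called first, only, known or untested is meant among the compounds shown, and "the series" means these compounds.

Compound 1 `CNCC(=O)Nc1cc(OC)ccc1C(=O)c1ccc(OC)c2c1C=CC(C)(C)O2` and compound 2 `CCNCC(=O)Nc1cc(OC)ccc1C(=O)c1ccc(OC)c2c1C=CC(C)(C)O2` share one core and differ only by methyl in place of hydrogen on a saturated chain carbon bound to an amine nitrogen. In a functional assay on HCT-8 cells (Homo sapiens) for antiproliferative activity, read by MTT assay, with a stated time of 48 h (on this read-out lower numbers stand for stronger inhibition and higher numbers for weaker inhibition), compound 1 gives 3460 nM, while compound 2 gives 7890 nM, a step of a 2.3-fold higher number from compound 1 to compound 2 (0.36 log units; beyond the scatter). Compound 3 `CNCC(=O)Nc1cc(OC)ccc1C(=O)c1cc(OC)c(OC)c(OC)c1` rests on a second core; the difference between the two cores is not broken down here. In this assay compound 3 gives 780 nM, the lowest of the three numbers, with both compound 1 and compound 2 lying beyond the scatter from it. Compound 4 `CCNCC(=O)Nc1cc(OC)ccc1C(=O)c1cc(OC)c(OC)c(OC)c1` has not yet been measured and differs from compound 3 by methyl in place of hydrogen on a saturated chain carbon bound to an amine nitrogen, the same change, at the same place, as that between compound 1 and compound 2. The change has so far been seen once only, on the core of compound 1, so its carry-over to the core of compound 3 is uncertain. Within the data shown here, compound 4 is expected to show a step of a 2.3-fold higher number from compound 3 to compound 4 (0.36 log units; beyond the scatter) because a 2.3-fold higher number from compound 1 to compound 2 (0.36 log units; beyond the scatter) is the only precedent available. Compound 4 is accordingly estimated at 1800 nM in this assay, between 900 nM and 4500 nM.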

Compound 4, half-maximal inhibitory concentration: 1560 nM
Compound 4: the middle estimate sits 1.2-fold (0.06 log units) above what was measured; low and high end bracket the measured number.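

In this assay, the change from methylamino to ethylamino on the core of compound 3 gives a 2.0-fold higher number from compound 3 to compound 4 (0.30 log units; within the scatter), so this step alone cannot be told apart from repeat measurement, unlike the earlier one on the core of compound 1. Set side by side, the two steps agree: the same change on two cores in this assay, a 2.3-fold higher number (0.36 log units; beyond the scatter) from compound 1 to compound 2 and a 2.0-fold higher number (0.30 log units; within the scatter) from compound 3 to compound 4, 1.1-fold (0.06 log units) apart, within the scatter of two such steps. This shows that, for these two pairs, the size of the step carried over from one core to the other, but it rests on one pair per core in one assay and does not establish a rule for other cores in the series, nor does it explain the step.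

The compounds shown leave open whether the same trend continues to a longer chain such as propyl, or to a branched group such as isopropyl, on the amine nitrogen. They also leave open how a tertiary amine such as dimethylamino would behave on either core.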